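Aryl variation on the cyclopentyl urea series

This account rests on a few compounds, and the source may have more. Where it says the series, first, only, none or still open, it means among the compounds named here.

Measured so far:
compound 1 `Cc1cccc(C2(CNC(=O)Nc3c(C(C)C)cccc3C(C)C)CCCC2)c1`: 15 nM
compound 2 `CC(C)c1cccc(C(C)C)c1NC(=O)NCC1(c2ccc(NCCO)cc2)CCCC1`: 25 nM
compound 3 `CC(C)c1cccc(C(C)C)c1NC(=O)NCC1(c2cccc(CO)c2)CCCC1`: 15 nM

Compound 3 stands level with compound 1 at the digits given in an assay on microsomes for inhibition of acyl-CoA:cholesterol acyltransferase (Oryctolagus cuniculus) (on this read-out lower numbers stand for stronger inhibition and higher numbers for weaker inhibition), the two of them together giving the lowest numbers of the three; compound 2 is the furthest, yet the step of a 1.7-fold lower number from compound 2 to compound 3 (0.22 log units; within the scatter) still lies within the scatter. The step of no change at the digits printed from compound 1 to compound 3 (within the scatter) shows that swapping the hydroxy on the saturated chain carbon for hydrogen leaves the read-out untouched, and the step of a 1.7-fold higher number from compound 1 to compound 2 (0.22 log units; within the scatter) shows the same for a larger exchange of the aryl substituent.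

Compound 4 `Cc1ccc(C2(CNC(=O)Nc3c(C(C)C)cccc3C(C)C)CCCC2)c(C)c1` differs from compound 3 in one place: 2,4-dimethylphenyl in place of 3-(hydroxymethyl)phenyl on a saturated ring carbon. Going by the values given here, the steps that bear on it are those between compounds 1, 2 and 3, all of which exchanged the substituent pattern on this same aryl ring and none of which moved this assay beyond the scatter. The loss of the hydrogen-bond donor and acceptor carried by the hydroxymethyl group is therefore not expected to change this assay beyond the scatter, since compound 1, which also carries only methyl on the ring, gives 15 nM.

Compound 4 is accordingly estimated at 15 nM, with a range of 6 nM to 40 nM, which means an expected step of no change at the digits printed from compound 3 to compound 4 (within the scatter).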

Compound 4, half-maximal inhibitory concentration: 50 nM
Estimate against measurement, compound 4: 3.3-fold (0.52 log units) below; the whole stated range lies below it.
By their numbers in this assay, from the lowest: compounds 1, 3, 2 and 4 (each within the scatter of the next, the first and the last beyond it).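

In this assay, going by these compounds alone, 2,4-dimethylphenyl on the saturated ring carbon gives the first exchange at this position to pass the scatter: a 3.3-fold higher number from compound 3 to compound 4 (0.52 log units; beyond the scatter), and the same size of change appears in a 3.3-fold higher number from compound 1 to compound 4 (0.52 log units; beyond the scatter), both modest, while a 2.0-fold higher number from compound 2 to compound 4 (0.30 log units; within the scatter) stays within the scatter, so compound 4 cannot be separated from compound 2 on this read-out. Compound 1 carries no hydroxy on its aryl group and stands level with compound 3, so the loss of the hydroxymethyl group alone does not account for the higher number of compound 4, and the comparison with compound 1 points instead to the change from 3-methylphenyl to 2,4-dimethylphenyl. No measurement beyond this read-out is available to explain the step.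

On these data alone, it remains open whether the step follows from one of the two methyl groups of 2,4-dimethylphenyl or needs both, as the series here holds only one dimethyl pattern. Also open, as far as these compounds go, is how an aryl group bearing a methoxy group, a primary amine or a carboxylic acid would read in this assay at this position.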